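Notes on the exocyclic aryl position: compound 4

This account rests on a few compounds, and the source may have more. Where it says the series, first, only, none or still open, it means among the compounds named here.

Compound 1, `O=C1N=C(N2CCC[C@H]2C(=O)Nc2ccc3ncnc(Nc4cccc(Cl)c4)c3c2)S/C1=C/c1ccccc1F`, in a functional assay on A549 cells (Homo sapiens) for antiproliferative activity, read by MTT assay (on this read-out lower numbers stand for stronger inhibition and higher numbers for weaker inhibition), gives 34500 nM.
Compound 2, `O=C1N=C(N2CCC[C@H]2C(=O)Nc2ccc3ncnc(Nc4cccc(Cl)c4)c3c2)S/C1=C/c1cccc(Br)n1`, in this assay gives 3100 nM.
Compound 3, `COc1ccccc1/C=C1/SC(N2CCC[C@H]2C(=O)Nc2ccc3ncnc(Nc4cccc(Cl)c4)c3c2)=NC1=O`, in this assay gives only a limit, > 50000 nM.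

Compound 2 stands lowest of the two numbers shown; its nearest neighbour is compound 1, with an 11-fold lower number from compound 1 to compound 2 (1.05 log units; beyond the scatter). Compound 3 sits at the limit of > 50000 nM in this assay, at which 1 of the 3 values shown sits.

Compound 4, `O=C1N=C(N2CCC[C@H]2C(=O)Nc2ccc3ncnc(Nc4cccc(Cl)c4)c3c2)S/C1=C/c1ccc2ccccc2n1`, is not yet measured. Its change from compound 2 is quinolin-2-yl in place of 6-bromopyridin-2-yl on a double-bonded chain carbon bound to a double-bonded ring carbon. The six-membered aromatic ring with 1 hetero atom stays; bromine goes and a six-membered aromatic ring of carbon only enters.

Among the compounds with values here, two measured steps bear on this position: an 11-fold lower number from compound 1 to compound 2 (1.05 log units; beyond the scatter) and an at least 16-fold higher number from compound 2 to compound 3 (1.20 log units; beyond the scatter). Both are large, so the group here moves the read-out strongly. Neither step, however, exchanges one ring of this kind for another, so no direction can be read from them for quinolin-2-yl. For compound 4 the expected step is a 1.6-fold higher number from compound 2 to compound 4 (0.21 log units; within the scatter), with wide bounds. Compound 4 is estimated at 5000 nM, between 1500 nM and 18000 nM.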

Compound 4, half-maximal inhibitory concentration: > 50000 nM
Compound 4 gave a limit, no number; the forecaster's own chance of this, stated with the estimate: 3%; middle value at least 10-fold (1.00 log units) away from the limit.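

Compound 4 gives only a limit in this assay, and it shares that limit with compound 3: the limit of > 50000 nM in this assay, at which 2 of the 4 values shown sit.

Exchanging 6-bromopyridin-2-yl for quinolin-2-yl gives an at least 16-fold higher number from compound 2 to compound 4 (1.20 log units; beyond the scatter), so the earlier large steps, which each swapped a phenyl group for the pyridine or back, now gain one in which a six-membered aromatic ring with 1 hetero atom stays and the read-out is still lost. Against the 2-fluorophenyl group, the result is only an at least 1.4-fold higher number from compound 1 to compound 4 (0.16 log units; that floor lies within the scatter), while the step between the two limits of compound 3 and compound 4 cannot be read.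

The compounds shown do not separate the part played by the bromine in compound 2 from that of the ring nitrogen. From the compounds shown here alone, how a pyridin-2-yl group without bromine, or one carrying an amine in its place, would read stays open.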